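Amide nitrogen substituent change from compound 3 to compound 4

This account rests on a few compounds, and the source may have more. Where it says the series, first, only, none or still open, it means among the compounds named here.

Measured so far:
compound 1 `CNC(=O)c1cc(C(=O)N[C@H]2[C@@H]3COC[C@@H]32)cc2c1OC[C@H]2c1cccnc1`: 1.4
compound 2 `CC[C@@]1(c2ccccc2)COc2c(C(=O)NC)cc(C(=O)N[C@H]3[C@@H]4COC[C@@H]43)cc21`: 4.2
compound 3 `CNC(=O)c1cc(C(=O)NC)c2c(c1)[C@](C)(c1ccccc1)CO2`: 3.4

The three compounds were characterised in a physicochemical assay for lipophilicity, at pH 7.4; on this read-out higher numbers stand for higher lipophilicity and lower numbers for lower lipophilicity. Compound 1 gives 1.4, compound 2 gives 4.2 and compound 3 gives 3.4. Compound 3 stands second highest of the three numbers; compound 2 lies nearest to it, a gap beyond the scatter, and compound 1 lies furthest, a larger gap also beyond the scatter.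

Compound 4 `CNC(=O)c1cc(C(=O)N[C@H]2[C@@H]3C[C@H](O)C[C@@H]32)cc2c1OC[C@@]2(C)c1ccccc1` has not been measured in this assay. It differs from compound 3 in one place: a group of 7 heavy atoms (6 carbon, 1 oxygen; one three-membered non-aromatic ring of carbon only, one five-membered non-aromatic ring of carbon only) in place of one carbon atom, on an amide-type nitrogen. For the measured compounds named here, no pair of measured compounds differs in exactly this way, so the size of the step is not known from the data. An upward step beyond the scatter is expected, since a group of seven heavy atoms with one hydrogen-bond donor and one hydrogen-bond acceptor replaces a single carbon atom.

Compound 4 is expected to give 4, within 3.4 to 4.6, which corresponds to an estimated step of a number 0.60 log units higher from compound 3 to compound 4 (beyond the scatter).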

Compound 4, distribution coefficient: 3.7
For compound 4 the middle estimate is 0.30 log units above the measured one, and the stated range covers the measured number.
By their numbers in this assay, from the lowest: compound 1; then compounds 3 and 4 (each within the scatter of the next); then compound 2.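

In this assay the number lies a number 0.30 log units higher from compound 3 to compound 4 (within the scatter) when methyl on an amide-type nitrogen gives way to a group of 7 heavy atoms, with one three-membered and one five-membered non-aromatic ring of carbon only, 1 hydrogen-bond donor and 1 hydrogen-bond acceptor. For the compounds shown here, this is the first single-place comparison, and it shows that, on this core, this large exchange at this nitrogen does not separate the two compounds in this read-out. Nothing available offers an explanation for this result.

As far as these compounds go, it remains open whether the same holds for other groups at this nitrogen, such as a primary amine, a carboxylic acid or a longer alkyl chain. From the compounds shown here alone, it is also open whether this exchange would give a similar step on another core.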